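This account rests on a few compounds, and the source may have more. Where it says the series, first, only, none or still open, it means among the compounds named here.

In an ADME assay on MT4 cells (Homo sapiens) for cytotoxicity, read by MTT assay (on this read-out lower numbers stand for higher toxicity in this test and higher numbers for lower toxicity in this test), compound 1 (`Cc1ccccc1C(=O)N(C(=S)OCCN1C(=O)c2ccccc2C1=O)c1ccc(Cl)cc1`) gives 21000 nM and compound 2 (`Cc1cc(C(=O)N(C(=S)OCCN2C(=O)c3ccccc3C2=O)c2ccc(Cl)cc2)ccc1Br`) gives 18000 nM with the two level within the scatter. Compound 3 (`O=C1c2ccccc2C(=O)N1CCOC(=S)N(C(=O)c1ccc2ccccc2c1)c1ccc(Cl)cc1`) comes next, with naphthalen-2-yl in place of 4-bromo-3-methylphenyl on a carbonyl carbon. Going by the values given here, the one measured step at that carbonyl carbon (a 1.2-fold lower number from compound 1 to compound 2 (0.07 log units; within the scatter)) stayed within the scatter, so no step beyond the scatter is expected in this assay for this change. The estimated step is small (a 1.1-fold higher number from compound 2 to compound 3 (0.02 log units; within the scatter)). For compound 3 the estimated value is 19000 nM with an expected range of 9000 nM to 40000 nM on this read-out.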

Compound 3, half-maximal cytotoxic concentration: 37000 nM
Estimate against measurement, compound 3: 1.9-fold (0.29 log units) below, and the stated range covers the measured number.
By their numbers in this assay, from the lowest: compounds 2, 1 and 3 (each within the scatter of the next, the first and the last beyond it).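

In this assay the carbonyl carbon now shows a step beyond the scatter, modest in size, with a 2.1-fold higher number from compound 2 to compound 3 (0.31 log units; beyond the scatter) as naphthalen-2-yl replaces 4-bromo-3-methylphenyl. Against 2-methylphenyl the same group gives a 1.8-fold higher number from compound 1 to compound 3 (0.25 log units; within the scatter) and stays within the scatter, so the reading of naphthalen-2-yl depends on the group it replaces. As far as these compounds go, whether an amine, a carboxylic acid or a longer chain on this carbonyl carbon would move the number further stays open. Nothing measured here bears on the reason for the step.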